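This account rests on a few compounds, and the source may have more. Where it says the series, first, only, none or still open, it means among the compounds named here.

In an ADME assay on a cell-free system (plasma, Homo sapiens) for protein binding, read by LC-MS, with a stated time of 5 h, tested at 5 uM, compound 2 `Cn1cnc(S(=O)(=O)N2CCS[C@H]2C(=O)O[C@@H](Cc2c(Cl)c[n+]([O-])cc2Cl)c2ccc(OC(F)F)c(OCC3CC3)c2)c1` gives 98.5%, while compound 1 `CNC(=O)c1cc(S(=O)(=O)N2CCS[C@H]2C(=O)O[C@@H](Cc2c(Cl)c[n+]([O-])cc2Cl)c2ccc(OC(F)F)c(OCC3CC3)c2)cn1C` gives 99.8%, so compound 2 has the higher unbound fraction of the two. Compound 3 `COc1ccc(S(=O)(=O)N2CCS[C@H]2C(=O)O[C@@H](Cc2c(Cl)c[n+]([O-])cc2Cl)c2ccc(OC(F)F)c(OCC3CC3)c2)cc1OC` keeps the rest of compound 2 and changes one group: 3,4-dimethoxyphenyl in place of 1-methyl-1H-imidazol-4-yl on a sulfonyl sulfur. Among the compounds with values here, only one measured step bears on this change: a 7.5-fold higher unbound fraction from compound 1 to compound 2 (0.88 log units; beyond the scatter). In that step, a larger group on the sulfonyl sulfur gave way to 1-methyl-1H-imidazol-4-yl. Compound 3 loses that same group and gains a larger one, though not the group carried by compound 1. One pair is thin evidence, but it points to less free compound in this assay, by a step somewhat smaller than the measured one. The expected change is a 3.0-fold lower unbound fraction from compound 2 to compound 3 (0.48 log units; beyond the scatter). The estimate for compound 3 is 99.5%, with an expected range from 98.5% to 99.9%.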

Compound 3, plasma protein binding: 99.6%
Compound 3: the middle estimate sits 1.3-fold (0.10 log units) (unbound fraction) above what was measured, and the stated range covers the measured number.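

In this assay, placing 3,4-dimethoxyphenyl on the sulfonyl sulfur in place of 1-methyl-1H-imidazol-4-yl gives a 3.8-fold lower unbound fraction from compound 2 to compound 3 (0.57 log units; beyond the scatter), so the imidazole group of compound 2 is now compared with two different larger groups rather than one. The two groups of 10 heavy atoms, one on a five-membered ring and one on a six-membered carbon ring, give a 2.0-fold higher unbound fraction from compound 1 to compound 3 (0.30 log units; within the scatter), so this assay does not separate them despite their different atoms. No measurement here explains why compound 2 has more free compound than the other two.

Compound 2 carries both the smallest group and the only ring with two hetero atoms, so size and ring type cannot be told apart. A small group such as methyl, or a plain phenyl ring of similar size to the imidazole, would help to separate them.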